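Cytotoxicity notes on a pyridyl-oxadiazole hydrazone series

A few compounds are considered here, and "the series" means these few. Any claim that something is new, unique, unknown or untested is made for them only; others in the source may bear on it.

Measured so far, in a functional assay on HepG2 cells (Homo sapiens) for cytotoxicity, read by MTT assay, with a stated time of 48 h; a higher number here means a weaker inhibitor, a lower number a stronger inhibitor:
- compound 1, `O=C(CSc1nnc(-c2ccncc2)o1)N/N=C/c1ccc(O)cc1`, gives 5510 nM
- compound 2, `O=C(CSc1nnc(-c2ccncc2)o1)N/N=C/c1ccccc1[N+](=O)[O-]`, gives 24700 nM
- compound 3, `O=C(CSc1nnc(-c2ccncc2)o1)N/N=C/c1ccccc1O`, gives 3510 nM

Among these three numbers compound 1 holds the second highest; its nearest neighbour is compound 3 and its furthest is compound 2. The measured steps are a 4.5-fold higher number from compound 1 to compound 2 (0.65 log units; beyond the scatter), a 1.6-fold lower number from compound 1 to compound 3 (0.20 log units; within the scatter) and a 7.0-fold lower number from compound 2 to compound 3 (0.85 log units; beyond the scatter). Only the nitro-bearing compound 2 moves beyond the scatter; the two hydroxy-bearing compounds sit within it of each other.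

Compound 4, `O=C(CSc1nnc(-c2ccncc2)o1)N/N=C/c1cc(Br)cc(Br)c1O`, is not yet measured. Relative to compound 1 the change is 3,5-dibromo-2-hydroxyphenyl in place of 4-hydroxyphenyl on a carbon with a double bond to nitrogen. The step from compound 1 to compound 3 bears on the hydroxy position and was within the scatter; nothing measured bears on the two bromines. The expectation in this assay is therefore a step of a 1.6-fold lower number from compound 1 to compound 4 (0.20 log units; within the scatter), not resolvable beyond the scatter, with a wide range to allow for the bromines. Compound 4 is estimated at 3500 nM, between 900 nM and 14000 nM.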

Compound 4, half-maximal inhibitory concentration: 6540 nM
Compound 4: the middle estimate sits 1.9-fold (0.27 log units) below what was measured; low and high end bracket the measured number.
By their numbers in this assay, from the lowest: compounds 3, 1 and 4 (each within the scatter of the next); then compound 2.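

In this assay, the two bromines of 3,5-dibromo-2-hydroxyphenyl produce no resolvable shift at this position: a 1.9-fold higher number from compound 3 to compound 4 (0.27 log units; within the scatter) and a 1.2-fold higher number from compound 1 to compound 4 (0.07 log units; within the scatter) both remain within the scatter. The larger group therefore stays level with the two hydroxy-bearing groups, whereas a 3.8-fold lower number from compound 2 to compound 4 (0.58 log units; beyond the scatter) lies beyond the scatter and leaves the 2-nitrophenyl compound apart from all three. No measurement on hand offers an explanation for these numbers.

The compounds shown leave open whether a single bromine would read the same as two, and whether chlorine or methyl in place of bromine would stay within the scatter. They also leave open whether an amine or a carboxylic acid on this aromatic ring would group with the hydroxy-bearing compounds or with compound 2.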